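Swapping the ring on the pyridazinone nitrogen of compound 2

The compounds below may be only part of what the source reports. "The series", "measured", "known", "first", "only" and "open" are said of these compounds alone.

Among the compounds with values here, compound 2 `COc1cc2c(Oc3ccc(NC(=O)c4nn(-c5ccccc5OC(F)(F)F)c(=O)cc4C)cc3F)ccnc2cc1OCCCN1CCCC1` gives the lower of the two numbers measured so far. In a functional assay on MKN-45 cells (Homo sapiens) for inhibition, read by MTT assay, with a stated time of 72 h (a higher number here means a weaker inhibitor, a lower number a stronger inhibitor), compound 2 gives 60 nM, while compound 1 `COc1cc2c(Oc3ccc(NC(=O)c4nn(-c5ccccc5C)c(=O)cc4C)cc3F)ccnc2cc1OCCCN1CCCC1` gives 760 nM. Within the data shown here, the only measured step, a 13-fold lower number from compound 1 to compound 2 (1.10 log units; beyond the scatter), shows that the group carried on this phenyl ring can move the number a great deal.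

Compound 3 `COc1cc2c(Oc3ccc(NC(=O)c4nn(-c5ccc(Cl)cc5)c(=O)cc4C)cc3F)ccnc2cc1OCCCN1CCCC1` changes that same ring again: 4-chlorophenyl in place of 2-(trifluoromethoxy)phenyl on an aromatic nitrogen. Among the measured compounds shown here, no measured pair shows chlorine on this ring or a group at this position, so the measured step is only indirect guidance. What it does show is that compound 2 owes its low number to the trifluoromethoxy group, which compound 3 no longer carries; the nearest comparison without it, compound 1, sits much higher. The expectation is therefore a number above compound 2 but not necessarily back at compound 1, expressed as an expected step of a 4.2-fold higher number from compound 2 to compound 3 (0.62 log units; beyond the scatter). For compound 3 in this assay the estimated value is 250 nM, expected to fall between 60 nM and 1000 nM.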

Compound 3, half-maximal inhibitory concentration: 150 nM
The estimate for compound 3 lay 1.7-fold (0.22 log units) above the measured number; measured number inside the range.
By their numbers in this assay, from the lowest: compound 2; then compound 3; then compound 1.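

In this assay, 4-chlorophenyl on this aromatic nitrogen gives a 5.1-fold lower number from compound 1 to compound 3 (0.70 log units; beyond the scatter), so a low number here does not depend on the trifluoromethoxy group alone. The 2-(trifluoromethoxy)phenyl ring still holds the lowest number of the three, with a 2.5-fold higher number from compound 2 to compound 3 (0.40 log units; beyond the scatter), which shows that the two rings are not interchangeable even though both beat 2-methylphenyl. The 4-chlorophenyl ring differs from the other two in both the group it carries and where that group stands, and nothing available here explains the differences among the three.

As far as these compounds go, it remains open how much of these steps comes from the kind of group and how much from where it stands on the ring, a question that a comparison of 2-chlorophenyl with 4-chlorophenyl, or of 4-(trifluoromethoxy)phenyl with 2-(trifluoromethoxy)phenyl, would help to settle. Also open, from the compounds shown here alone, is how a plain phenyl ring, or a phenyl ring carrying an amine or a carboxylic acid, would compare with these three.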